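Dropping the side chain entirely: compound 4 expected modest

The source may report more compounds than this note shows. Statements on the series, on what has been measured and on what is new or still open speak of the compounds shown alone.

Measured in a functional assay on the whole organism (Tail, strain ICR) with Mus musculus as the target, in the tail flick test, with a stated time of 90 min, at a dose of 25 umol/kg by the oral route; a higher number here means a stronger effect of the compound at the dose given, a lower number a weaker effect:
Compound 1, `C[C@@H](O)[C@H](NC(=O)CN(c1nc(Cl)nc2[nH]cnc12)C1CC1)C(=O)O`, gives 35.9%.
Compound 2, `CSCC[C@H](NC(=O)CN(c1nc(Cl)nc2[nH]cnc12)C1CC1)C(=O)O`, gives 14%.
Compound 3, `CC[C@H](C)[C@H](NC(=O)CN(c1nc(Cl)nc2[nH]cnc12)C1CC1)C(=O)O`, gives 27.4%.

Compound 3 stands second highest of the three numbers in this assay: the gap to compound 1 is within the usual scatter, while the gap to compound 2 lies beyond it. The three compounds share one core and differ only in the group on the saturated chain carbon bound to an amide-type nitrogen and a carbonyl carbon. Compound 4, `O=C(O)CNC(=O)CN(c1nc(Cl)nc2[nH]cnc12)C1CC1`, carries no group there at all: hydrogen in place of sec-butyl on a saturated chain carbon bound to an amide-type nitrogen and a carbonyl carbon.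

The measured steps all swap one side chain for another, none removes one. Those swaps moved the read-out modestly or not at all: a number 8.5 percentage points lower from compound 1 to compound 3 (within the scatter), a number 13.4 percentage points higher from compound 2 to compound 3 (beyond the scatter), and a number 21.9 percentage points lower from compound 1 to compound 2 (beyond the scatter). Going by the values given here, since every change at this position so far has stayed modest, and the change to hydrogen is the largest shrinkage yet, the step of a number 5.4 percentage points lower from compound 3 to compound 4 (within the scatter) is expected to be a modest lowering, possibly within the scatter. For compound 4 the estimate in this assay is 22%, with a plausible range from 8% to 38%.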

Compound 4, a percentage reported as activity, at one dose (the size of the read-out at that dose, not a potency): 32.3%
Compound 4: middle estimate off by 10.3 percentage points, on the low side; measured number inside the range.
By their numbers in this assay, from the lowest: compound 2; then compounds 3, 4 and 1 (each within the scatter of the next).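

In this assay, going by these compounds alone, the earlier compounds only swapped one side chain for another, whereas compound 4 shows what happens with no side chain at this position. Hydrogen in place of sec-butyl gives a number 4.9 percentage points higher from compound 3 to compound 4 (within the scatter) and hydrogen in place of 1-hydroxyethyl gives a number 3.6 percentage points lower from compound 1 to compound 4 (within the scatter), so among these three compounds the side chain is not required for the effect at this dose. Compound 2 is the one that stands apart, with hydrogen in place of 2-(methylsulfanyl)ethyl giving a number 18.3 percentage points higher from compound 2 to compound 4 (beyond the scatter), which makes it the lowest of the four, though nothing in the data explains this.

The compounds shown leave open whether the lower number of compound 2 belongs to its sulfur atom or to its chain, and whether a side chain ending in an amine, a second carboxylic acid or a benzyl group at this position would raise the read-out above that of compound 4 or lower it as 2-(methylsulfanyl)ethyl does. As far as these compounds go, each number also comes from a single dose, so how potency changes across these compounds remains open as well.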